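The source may report more compounds than this note shows. Statements on the series, on what has been measured and on what is new or still open speak of the compounds shown alone.

Compound 1 `O=[N+]([O-])c1ccc(CN2CCC(n3cc(CC(OCc4cc(-c5cccc(F)c5)no4)c4ccc(Br)cc4)nn3)CC2)cc1` was tested in a functional assay on Huh-7 cells (Homo sapiens) for cytotoxicity, with a stated time of 48 h (on this read-out lower numbers stand for stronger inhibition and higher numbers for weaker inhibition), where compound 1 gives 3000 nM. Its closest measured neighbour is compound 2 `N#Cc1cccc(-c2cc(COC(Cc3cn(C4CCN(Cc5ccc([N+](=O)[O-])cc5)CC4)nn3)c3ccc(Br)cc3)on2)c1`, which carries a cyano in place of fluoro on an aromatic carbon; in this assay compound 2 gives 3000 nM. The step of no change at the digits printed from compound 1 to compound 2 (within the scatter), so compound 1 stands level with compound 2 at the digits shown.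

Compound 3 `COc1ccccc1-c1cc(COC(Cc2cn(C3CCN(Cc4ccc([N+](=O)[O-])cc4)CC3)nn2)c2ccc(Br)cc2)on1` differs from compound 1 by 2-methoxyphenyl in place of 3-fluorophenyl on an aromatic carbon, a swap of the whole aryl group on the five-membered aromatic ring with one nitrogen and one oxygen. Among the measured compounds shown here, the only measured step that bears on this position, from compound 1 to compound 2, altered the same aryl group and stayed within the scatter. For compound 3 a step of about no change at the digits printed from compound 1 to compound 3 (within the scatter) is therefore expected, with no clear direction. The estimate for compound 3 in this assay is 3000 nM, within a range from 1000 nM to 9000 nM.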

Compound 3, half-maximal inhibitory concentration: 5000 nM
Compound 3: the middle estimate sits 1.7-fold (0.22 log units) below what was measured, and the stated range covers the measured number.
By their numbers in this assay, from the lowest: compounds 1, 2 and 3 (each within the scatter of the next).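

In this assay, 2-methoxyphenyl gives a 1.7-fold higher number from compound 1 to compound 3 (0.22 log units; within the scatter), and set against 3-cyanophenyl it gives a 1.7-fold higher number from compound 2 to compound 3 (0.22 log units; within the scatter). Among the compounds shown here, the earlier pair compared only two groups named with a 3-substituent, whereas this result adds a 2-substituted phenyl group whose methoxy brings one hydrogen-bond acceptor, and compounds 1, 2 and 3 still lie within the scatter of one another. Nothing available here explains why these aryl groups do not separate.

As far as these compounds go, all three compounds carry a substituted phenyl group at this position, so it remains open whether a carboxylic acid on that phenyl ring, or a plain methyl in place of the whole aryl group, would shift the number beyond the scatter. From the compounds shown here alone, the effect of changes elsewhere on the shared core also remains open.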